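Thiazolyl amide in place of the chloro-trifluoromethylphenyl tail

This account rests on a few compounds, and the source may have more. Where it says the series, first, only, none or still open, it means among the compounds named here.

compound 1, `CNc1ncnc2c(CNc3cc(NC(=O)c4ccc(Cl)c(C(F)(F)F)c4)ccc3C)cccc12`: 9700 nM
compound 2, `CNc1ncnc2c(CNc3cc(NC(=O)c4ccc(-c5cc(C(F)(F)F)ccc5Cl)o4)ccc3C)cccc12`: 14900 nM

Both were tested in a functional assay on A375P cells (Homo sapiens) for cytotoxicity, read by MTT assay, with a stated time of 24 h; on this read-out higher numbers stand for weaker inhibition and lower numbers for stronger inhibition. Compound 1 gives the lowest of the two numbers, and compound 2 lies only slightly higher, within the usual scatter, so the two cannot be told apart on this assay. Compound 3 `CNc1ncnc2c(CNc3cc(NC(=O)c4cscn4)ccc3C)cccc12` has not been measured; it differs from compound 1 in one place: 1,3-thiazol-4-yl in place of 4-chloro-3-(trifluoromethyl)phenyl on a carbonyl carbon. No comparable exchange between measured compounds is available here, so the expectation rests on the measured numbers and the change alone. A step toward weaker inhibition, somewhat beyond the scatter, is expected, a 2.6-fold higher number from compound 1 to compound 3 (0.41 log units; beyond the scatter). Compound 3 is therefore estimated at about 25000 nM, within a range from 8000 nM to 80000 nM.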

Compound 3, half-maximal inhibitory concentration: 1900 nM
Compound 3: middle estimate off by 13-fold (1.12 log units), on the high side; measured number below the stated range.
By their numbers in this assay, from the lowest: compound 3; then compounds 1 and 2 (each within the scatter of the next).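

In this assay the carbonyl carbon of the amide accepts a smaller tail: 1,3-thiazol-4-yl in place of 4-chloro-3-(trifluoromethyl)phenyl gives a 5.1-fold lower number from compound 1 to compound 3 (0.71 log units; beyond the scatter) and so stronger inhibition. The large chlorine- and fluorine-bearing phenyl tail is therefore not required for activity here. Nothing shown explains why this exchange strengthens inhibition.

Still open, on these data alone, is whether the improvement depends on the ring's nitrogen and sulfur atoms or only on the smaller tail. An unsubstituted phenyl, a pyridyl or a cyclopropyl at this position would help separate those possibilities.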